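Removing a Chloro Group on a Different Core

This account rests on a few compounds, and the source may have more. Where it says the series, first, only, none or still open, it means among the compounds named here.

Measured compounds:
compound 1, `COc1ccc(-c2nc(C)c(C(=O)CSc3nc(N)c(C#N)c(-c4ccc(Cl)cc4)n3)s2)cc1`, 23.1%
compound 2, `COc1ccc(-c2nc(C)c(C(=O)CSc3nc(N)c(C#N)c(-c4ccccc4)n3)s2)cc1`, 16.5%
compound 3, `Cc1nc(-c2ccc(Cl)cc2)sc1C(=O)CSc1nc(-c2ccc(Cl)c(Cl)c2)c(C#N)c(=O)[nH]1`, 93.9%

In a functional assay on U-87MG ATCC cells for antiproliferative activity against U-87 MG (Homo sapiens), read by MTT assay, with a stated time of 48 h, tested at 50 uM (a higher number here means a weaker effect of the compound at the concentration tested, a lower number a stronger effect), compound 1 gives 23.1% and compound 2 gives 16.5%. The step of a number 6.6 percentage points lower from compound 1 to compound 2 (within the scatter) is the change (hydrogen in place of chloro on an aromatic carbon). Compound 3 gives 93.9% in this assay, the highest of the three numbers. The difference between the cores of compound 1 and compound 3 is not broken down here.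

Compound 4, `Cc1nc(-c2ccc(Cl)cc2)sc1C(=O)CSc1nc(-c2cccc(Cl)c2)c(C#N)c(=O)[nH]1`, arises from compound 3 by hydrogen in place of chloro on an aromatic carbon. This is the same kind of change as in compound 2, but here the place is ortho to a chloro group and para to a large group, whereas in compound 2 it was only para to a large group. Because a number 6.6 percentage points lower from compound 1 to compound 2 (within the scatter) stayed within the scatter, a similarly small step is expected, a number 3.9 percentage points lower from compound 3 to compound 4 (within the scatter). Compound 4 is therefore estimated at 90% in this assay, between 72% and 100%.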

Compound 4, a percentage reported as activity, at one concentration (the size of the read-out at that concentration, not a potency): 52.6%
Estimate against measurement, compound 4: 37.4 percentage points above; measured number below the stated range.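

In this assay, replacing 3,4-dichlorophenyl with 3-chlorophenyl gives a number 41.3 percentage points lower from compound 3 to compound 4 (beyond the scatter). Set beside the earlier step, this shows that the same change does not bring a step of the same size on these two cores: the same change on two cores in this assay, a number 6.6 percentage points lower (within the scatter) from compound 1 to compound 2 and a number 41.3 percentage points lower (beyond the scatter) from compound 3 to compound 4, 34.7 percentage points apart, beyond the scatter of two such steps It does not show which feature of the cores matters, since there is only one pair for each core and the chloro group also has different surroundings in the two pairs, so no rule for other cores follows.

From the compounds shown here alone, it remains open how a fluoro group or a carboxylic acid in the same place would compare with chloro and hydrogen on each core. Going by these compounds, the effect of removing the remaining chloro group from compound 4 also remains open.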